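Piperidin-1-yl in place of the sulfonamide-bearing amide tail

The compounds below may be only part of what the source reports. "The series", "measured", "known", "first", "only" and "open" are said of these compounds alone.

For the measured compounds named here, in an assay on HEK293 cells for displacement of a labelled ligand from NPC1-like intracellular cholesterol transporter 1 (Homo sapiens) (on this read-out higher numbers stand for weaker inhibition and lower numbers for stronger inhibition), compound 3 `CS(=O)(=O)NCCCNC(=O)CN1CN(c2ccccc2)C2(CCN(C(=O)c3ccc(C4CCCCC4)cc3)CC2)C1=O` gives 3800 nM, the second highest of the three numbers so far; compound 1 `O=C(CN1CN(c2ccccc2)C2(CCN(C(=O)c3ccc(C4CCCCC4)cc3)CC2)C1=O)NCCO` gives 2000 nM and compound 2 `COC(=O)CCNC(=O)CN1CN(c2ccccc2)C2(CCN(C(=O)c3ccc(C4CCCCC4)cc3)CC2)C1=O` gives 12900 nM. The step of a 1.9-fold higher number from compound 1 to compound 3 (0.28 log units; within the scatter) lies within the scatter, whereas a 3.4-fold lower number from compound 2 to compound 3 (0.53 log units; beyond the scatter) is beyond it. Compound 4 `O=C(CN1CN(c2ccccc2)C2(CCN(C(=O)c3ccc(C4CCCCC4)cc3)CC2)C1=O)N1CCCCC1` carries piperidin-1-yl in place of (3-(methanesulfonamido)propyl)amino on a carbonyl carbon. The measured steps only exchange groups two bonds along the chain from an amide-type nitrogen; none removes that nitrogen together with its chain in favour of a ring with 0 hydrogen-bond donors and 0 hydrogen-bond acceptors, so they bear on this change only loosely, and they were at most modest. The expected step in this assay is therefore a 1.2-fold higher number from compound 3 to compound 4 (0.07 log units; within the scatter), with no clear direction. Compound 4 is estimated at 4500 nM, within a range of 1500 nM to 14000 nM.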

Compound 4, half-maximal inhibitory concentration: 1100 nM
Estimate against measurement, compound 4: 4.1-fold (0.61 log units) above; measured number below the stated range.
By their numbers in this assay, from the lowest: compounds 4, 1 and 3 (each within the scatter of the next, the first and the last beyond it); then compound 2.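

At the carbonyl carbon, piperidin-1-yl is tolerated in this assay, with lower numbers than two of the open-chain amide tails (a 3.5-fold lower number from compound 3 to compound 4 (0.54 log units; beyond the scatter); a 12-fold lower number from compound 2 to compound 4 (1.07 log units; beyond the scatter)), while the comparison with the hydroxyethyl tail stays within the scatter (a 1.8-fold lower number from compound 1 to compound 4 (0.26 log units; within the scatter)). Activity at this position therefore needs neither the methanesulfonamide nor the amide hydrogen of these tails. Nothing measured here explains the differences.

From the compounds shown here alone, whether the lower numbers follow from the ring itself or from loss of the amide hydrogen remains open, and dimethylamino would separate the two. Morpholin-4-yl, pyrrolidin-1-yl and a piperidine bearing a carboxylic acid also remain open.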